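A few compounds are considered here, and "the series" means these few. Any claim that something is new, unique, unknown or untested is made for them only; others in the source may bear on it.

The measured compounds and their values:

compound 1, `CC(C)(C)OC(=O)N1CCC(O[C@H]2CC[C@@H](Oc3ccc(S(C)(=O)=O)cc3)CC2)CC1`: 1390 nM
compound 2, `CC(C)(C)OC(=O)N1CCC(O[C@H]2CC[C@H](Oc3ccc(S(C)(=O)=O)cc3)CC2)CC1`: 94 nM

In a functional assay on isolated protein for agonist activity at Glucose-dependent insulinotropic receptor (Rattus norvegicus), read by HTRF and cAMP accumulation (on this read-out higher numbers stand for an effect only at larger amounts of compound and lower numbers for an effect already at smaller amounts), compound 2 gives 94 nM, the lower of the two numbers, and compound 1 gives 1390 nM. Going by the values given here, the only measured step, a 15-fold lower number from compound 1 to compound 2 (1.17 log units; beyond the scatter), is large, and it rests on (the fact that compounds 1 and 2 differ only in the configuration as drawn).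

Compound 3, `CC(C)(C)OC(=O)N1CCC(O[C@H]2CC[C@H](Oc3ccc(S(C)(=O)=O)cc3F)CC2)CC1`, differs from compound 2 by fluoro in place of hydrogen on an aromatic carbon. Among the compounds with values here, no measured step touches a change of this kind: the one step available concerns configuration alone, and the two measured compounds carry the same aromatic ring with a hydrogen at that position. There is therefore no basis from these data for predicting a shift in either direction, and the expected change from compound 2 to compound 3 is none beyond the scatter. For compound 3 the estimated value is 94 nM, with a range from 35 nM to 250 nM. This estimate is expected to mean no change at the digits printed from compound 2 to compound 3 (within the scatter).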

Compound 3, half-maximal effective concentration: 61 nM
Beside the measured number, compound 3's estimate is 1.5-fold (0.19 log units) above it; the range from low to high includes it.
By their numbers in this assay, from the lowest: compounds 3 and 2 (each within the scatter of the next); then compound 1.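

In this assay, fluoro in place of hydrogen on an aromatic carbon, ortho to a large group and meta to a methylsulfonyl group, gives a 1.5-fold lower number from compound 2 to compound 3 (0.19 log units; within the scatter), so the scatter cannot separate this change from no change at all. The earlier compounds shown here carried only hydrogen at this place and so said nothing about it; this pair shows that the place accepts a fluorine atom while the number stays within the scatter of compound 2. Nothing given here speaks to why the change has this outcome.

From the compounds shown here alone, whether a chlorine atom, a methyl group, a methoxy group or a nitrile at the same place would also leave the number within the scatter remains open. So does whether fluoro would have the same outcome in the configuration of compound 1.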